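Hydroxamate series: cap exchange toward compound 4

This account rests on a few compounds, and the source may have more. Where it says the series, first, only, none or still open, it means among the compounds named here.

Measured in a functional assay on NFF cells (Homo sapiens) for antiproliferative activity; a higher number here means a weaker inhibitor, a lower number a stronger inhibitor:
compound 1 `O=C(CCCCC[C@H](NC(=O)c1ccc(Br)cc1)C(=O)NCc1ccncc1)NO` gives 5240 nM
compound 2 `O=C(CCCCC[C@H](NC(=O)OCc1ccccc1)C(=O)NCc1ccncc1)NO` gives 23300 nM
compound 3 `O=C(CCCCC[C@H](NC(=O)OCc1ccccc1)C(=O)Nc1ccc(-c2ccccc2)cc1)NO` gives 2200 nM

Compound 3 holds the lowest number of the three, with compound 1 nearest and compound 2 furthest. Two single changes run out of compound 2. The first, (4-bromophenyl in place of benzyloxy on a carbonyl carbon), gives a 4.4-fold lower number from compound 2 to compound 1 (0.65 log units; beyond the scatter). The second, (4-phenylphenyl in place of (pyridin-4-yl)methyl on an amide-type nitrogen), gives an 11-fold lower number from compound 2 to compound 3 (1.02 log units; beyond the scatter) and is also how the core of compound 3 differs from the core of compound 2.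

Compound 4 `O=C(CCCCC[C@H](NC(=O)c1ccc(Br)cc1)C(=O)Nc1ccc(-c2ccccc2)cc1)NO` is not yet measured. It differs from compound 3 by 4-bromophenyl in place of benzyloxy on a carbonyl carbon. This is the same change as that from compound 2 to compound 1, at the same place, now made on the core of compound 3; among the compounds here it occurs twice. Whether the two changes add on the core of compound 3 is not shown, so the range is kept wide.

Compound 4 is expected to show a step of a 3.7-fold lower number from compound 3 to compound 4 (0.56 log units; beyond the scatter) in this assay, resting on the step of a 4.4-fold lower number from compound 2 to compound 1 (0.65 log units; beyond the scatter). The estimate for compound 4 is 600 nM, between 250 nM and 1500 nM.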

Compound 4, half-maximal inhibitory concentration: 190 nM
Compound 4: middle estimate off by 3.2-fold (0.50 log units), on the high side; the whole stated range lies above it.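

In this assay, 4-bromophenyl in place of benzyloxy on a carbonyl carbon gives a 12-fold lower number from compound 3 to compound 4 (1.06 log units; beyond the scatter), so the change lowers the number on the core of compound 3 as it did on the core of compound 2. The larger size of the new step does not set the two cores apart: the same change on two cores in this assay, a 4.4-fold lower number (0.65 log units; beyond the scatter) from compound 2 to compound 1 and a 12-fold lower number (1.06 log units; beyond the scatter) from compound 3 to compound 4, 2.6-fold (0.42 log units) apart, within the scatter of two such steps. This supports carrying the change between these two cores in this assay, but it does not show that the step has a fixed size, that the cores differ in their response, or that the change would carry to any further core.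

The compounds shown leave open whether the step depends on the bromine or on the phenyl ring, a question that a plain phenyl on the same carbonyl carbon would address. Also open, from the compounds shown here alone, is whether the same change holds with a longer chain ahead of the hydroxamic acid, or with a carboxylic acid in its place.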